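Amide partner variation at the carbonyl carbon

The source may hold more compounds than are shown below. What is called first, only, known or untested is meant among the compounds shown, and "the series" means these compounds.

Compound 1 `COC1CC(C(=O)N2CCc3nc(C#Cc4ccccc4)sc3C2)C1`: > 10000 nM in an assay on HEK293 cells for negative allosteric modulation of metabotropic glutamate receptor 5 (Homo sapiens), read by FLIPR, with a stated time of 1 h (on this read-out lower numbers stand for stronger inhibition and higher numbers for weaker inhibition), a limit of the assay.
Compound 2 `O=C(C1CCCO1)N1CCc2nc(C#Cc3ccccc3)sc2C1`: > 10000 nM, likewise a limit.
Compound 3 `CC1CCC(C(=O)N2CCc3nc(C#Cc4ccccc4)sc3C2)CC1`: > 10000 nM, again a limit.

Compound 3 stands at the limit, as do both other measured compounds (the limit of > 10000 nM in this assay, at which 3 of the 3 values shown sit); no number is known for it. Compound 4 `O=C(N1CCC(F)CC1)N1CCc2nc(C#Cc3ccccc3)sc2C1` differs from it as follows: 4-fluoropiperidin-1-yl in place of 4-methylcyclohexyl on a carbonyl carbon. The measured steps that touch this position are a step that the two limits leave unreadable from compound 1 to compound 3, a step that the two limits leave unreadable from compound 2 to compound 3 and a step that the two limits leave unreadable from compound 1 to compound 2; each is unreadable in size and direction. Within the data shown here, no measured step therefore gives a size or direction for the change to compound 4, and the expectation rests only on the shared limit (the limit of > 10000 nM in this assay, at which 3 of the 3 values shown sit). Compound 4 is expected to remain near that limit, so the step of a number no higher from compound 3 to compound 4 (the limit leaves the size open) is estimated as small. The estimate for compound 4 is 10000 nM, ranging from 3000 nM to 30000 nM.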

Compound 4, half-maximal inhibitory concentration: > 10000 nM
Compound 4 gave a limit, no number (the forecaster's own chance of this, stated with the estimate: 70%); the middle value lies on the limit itself.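

Compound 4 joins compound 1, compound 2 and compound 3 at a limit, so no step among these compounds can be read in size or direction: the limit of > 10000 nM in this assay, at which 4 of the 4 values shown sit.

The compounds shown leave open whether any amide partner on this carbonyl carbon gives a readable number in this assay at all.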